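Removing a Methoxy Group on a Shared Core

A few compounds are considered here, and "the series" means these few. Any claim that something is new, unique, unknown or untested is made for them only; others in the source may bear on it.

Measured compounds:
compound 1, `COc1ccc(-c2cc(C(=O)/C=C/c3ccccc3)nc3cc(-c4ccccc4)nn23)cc1OC`: 18600 nM
compound 2, `COc1ccc(/C=C/C(=O)c2cc(-c3ccc(OC)c(OC)c3)n3nc(-c4ccccc4)cc3n2)cc1`: 19300 nM
compound 3, `COc1ccc(C(=O)/C=C/c2cc(-c3ccc(OC)c(OC)c3)n3nc(-c4ccccc4)cc3n2)cc1`: 11900 nM

In a functional assay on A549 cells (Homo sapiens) for antiproliferative activity, read by MTT assay, with a stated time of 24 h (on this read-out lower numbers stand for stronger inhibition and higher numbers for weaker inhibition), compound 1 gives 18600 nM, compound 2 gives 19300 nM and compound 3 gives 11900 nM. The three numbers sit close together. Compound 2 and compound 1 differ by hydrogen in place of methoxy on an aromatic carbon, a change that brought a 1.0-fold lower number from compound 2 to compound 1 (0.02 log units; within the scatter). Compound 2 and compound 3 share the same atoms joined differently, (2-((4-methoxyphenyl)carbonyl)ethenyl in place of (2-(4-methoxyphenyl)ethenyl)carbonyl on an aromatic carbon), with a 1.6-fold lower number from compound 2 to compound 3 (0.21 log units; within the scatter); compound 1 and compound 3 show a 1.6-fold lower number from compound 1 to compound 3 (0.19 log units; within the scatter).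

Compound 4, `COc1ccc(C(=O)/C=C/c2cc(-c3ccc(OC)cc3)n3nc(-c4ccccc4)cc3n2)cc1`, is not yet measured. It differs from compound 3 by hydrogen in place of methoxy on an aromatic carbon. This is the same kind of change as that from compound 2 to compound 1, but the place differs: there the leaving methoxy stood para to a large group, here it stands ortho to a methoxy group (2 heavy atoms) and meta to a large group, and the two cores differ as told by 2-((4-methoxyphenyl)carbonyl)ethenyl in place of (2-(4-methoxyphenyl)ethenyl)carbonyl on an aromatic carbon. Resting on compound 2 and compound 1, where the change gave a 1.0-fold lower number from compound 2 to compound 1 (0.02 log units; within the scatter), the step from compound 3 to compound 4 is expected to be a 1.1-fold higher number from compound 3 to compound 4 (0.02 log units; within the scatter). Compound 4 is therefore estimated at 12500 nM. Its value is expected to fall between 6000 nM and 26000 nM.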

Compound 4, half-maximal inhibitory concentration: 2900 nM
Compound 4: middle estimate off by 4.3-fold (0.63 log units), on the high side, outside the stated range (below it).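

In this assay, replacing one methoxy group with hydrogen, which turns 3,4-dimethoxyphenyl into 4-methoxyphenyl, gave a 4.1-fold lower number from compound 3 to compound 4 (0.61 log units; beyond the scatter). The same kind of change had done far less on the other core: the same change on two cores in this assay, a 1.0-fold lower number (0.02 log units; within the scatter) from compound 2 to compound 1 and a 4.1-fold lower number (0.61 log units; beyond the scatter) from compound 3 to compound 4, 4.0-fold (0.60 log units) apart, beyond the scatter of two such steps This shows that, among these compounds, the change cannot be carried from one core to another as a fixed step, but it does not show why: the two pairs differ in their cores and also in which ring loses its methoxy group, and two pairs cannot separate these.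

As far as these compounds go, it remains open whether the same removal from the 3,4-dimethoxyphenyl group on the core of compound 2 would repeat the step seen for compound 4. From the compounds shown here alone, it is also open whether a hydroxy group or an amine in place of that methoxy group would move the number in the same way as hydrogen.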